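Amide-to-ester exchange at the carbonyl of the shared core

A few compounds are considered here, and "the series" means these few. Any claim that something is new, unique, unknown or untested is made for them only; others in the source may bear on it.

Compound 1 `CCN(CC)CCNC(=O)c1ccc(C(CC)(CC)c2ccc(OCC(=O)C(C)(C)C)c(C)c2)n1CC` gives 30 nM in a functional assay on PC-3 cells (Homo sapiens), read by MTT assay, with a stated time of 48 h; on this read-out higher numbers stand for weaker inhibition and lower numbers for stronger inhibition. Compound 3 `CC[C@@H](C)[C@H](NC(=O)c1ccc(C(CC)(CC)c2ccc(OCC(=O)C(C)(C)C)c(C)c2)n1CC)C(=O)O` gives 1600 nM in this assay, and the step of a 53-fold higher number from compound 1 to compound 3 (1.73 log units; beyond the scatter) shows how much the group on the amide-type nitrogen can move the read-out. Compound 2 `CCn1c(C(=O)NCC(OC)OC)ccc1C(CC)(CC)c1ccc(OCC(O)C(C)(C)C)c(C)c1` gives 14600 nM in this assay and stands highest of the three numbers; its number sits well above that of compound 3 and far above that of compound 1, though compound 2 differs from each of them in more than one place.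

Compound 4 `CCn1c(C(=O)OCc2ccc(F)cc2)ccc1C(CC)(CC)c1ccc(OCC(O)C(C)(C)C)c(C)c1` differs from compound 2 in one place: (4-fluorobenzyl)oxy in place of (2,2-dimethoxyethyl)amino on a carbonyl carbon. Among the compounds with values here, no measured step covers an exchange of this kind at the carbonyl carbon. Within the data shown here, the only measured step, a 53-fold higher number from compound 1 to compound 3 (1.73 log units; beyond the scatter), swaps one group on the amide-type nitrogen for another and was large, so the carbonyl region is sensitive, but it gives no direction for an ester in place of an amide. The step of a 1.6-fold lower number from compound 2 to compound 4 (0.21 log units; within the scatter) is therefore expected to be small, with wide uncertainty either way. Compound 4 is expected to give 9000 nM, within 1500 nM to 50000 nM.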

Compound 4, half-maximal inhibitory concentration: > 50000 nM
Compound 4: no number, only a limit (the forecaster's own chance of this, stated with the estimate: 15%); at least 5.5-fold (0.74 log units) between middle value and limit.
By their numbers in this assay, from the lowest: compound 1; then compound 3; then compound 2. At a limit, above all of these: compound 4.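

Compound 4 gives no number, only a limit of the assay: the limit of > 50000 nM in this assay, at which 1 of the 4 values shown sits. Going by these compounds, the step of an at least 3.4-fold higher number from compound 2 to compound 4 (0.53 log units; beyond the scatter) is therefore a minimum size, and its true size stays unknown. Within the data shown here, until now the only single-place step changed one amide group for another, whereas this one shows that replacing (2,2-dimethoxyethyl)amino with (4-fluorobenzyl)oxy on the carbonyl carbon, which also removes the amide hydrogen and adds an aromatic ring, weakens inhibition even from a weak starting point.

The compounds shown do not separate the ester link from the 4-fluorobenzyl group, a question that an amide carrying 4-fluorobenzyl on its nitrogen or an ester carrying 2,2-dimethoxyethyl would address. Also open, on these data alone, is whether an ester carrying a tertiary amine, such as 2-(diethylamino)ethyl, would behave in the same way.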